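The source may hold more compounds than are shown below. What is called first, only, known or untested is meant among the compounds shown, and "the series" means these compounds.

Going by the values given here, compound 2 `O=C(O)Cn1c(SCCNc2ccccc2)nc2ccccc21` gives 7690 nM in an assay on HEK293 cells for displacement of a labelled ligand from prostaglandin D2 receptor 2 (Homo sapiens) (a lower number here means a stronger inhibitor, a higher number a weaker inhibitor), the highest of the two numbers measured so far. Its nearest neighbour, compound 1 `O=C(O)Cn1c(SCCCc2ccccc2)nc2ccccc21`, gives 475 nM in this assay. Among the compounds with values here, the one measured step between them is a 16-fold higher number from compound 1 to compound 2 (1.21 log units; beyond the scatter), a large loss in this assay for a change at the same place in the chain. Compound 3 `CCOC(=O)CCCCCSc1nc2ccccc2n1CC(=O)O` has not yet been measured. It differs from compound 2 in one place: 3-(ethoxycarbonyl)propyl in place of anilino on a saturated chain carbon, two bonds along the chain from a sulfur. Within the data shown here, no measured step bears directly on this exchange; the step from compound 1 to compound 2 only shows that the group at this place can shift the number by a large amount, and both measured compounds carry an aromatic ring that compound 3 lacks. The direction is therefore uncertain, and the estimate stays near the number of compound 2 with a wide range. Compound 3 is expected to give 5000 nM in this assay, somewhere between 1500 nM and 20000 nM. That expectation corresponds to an estimated step of a 1.5-fold lower number from compound 2 to compound 3 (0.19 log units; within the scatter), within the scatter.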

Compound 3, half-maximal inhibitory concentration: 1010 nM
The estimate for compound 3 lay 5.0-fold (0.69 log units) above the measured number; the measured number lies below the stated range.
By their numbers in this assay, from the lowest: compound 1; then compound 3; then compound 2.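

In this assay, 3-(ethoxycarbonyl)propyl in place of anilino gives a 7.6-fold lower number from compound 2 to compound 3 (0.88 log units; beyond the scatter) and so shows that a group with no ring can sit at this place on the chain and still give a much lower number than anilino does. The earlier loss of a 16-fold higher number from compound 1 to compound 2 (1.21 log units; beyond the scatter) therefore does not mean that every replacement of the benzyl end of the chain costs that much, although the ester chain does not fully match it: the step is a 2.1-fold higher number from compound 1 to compound 3 (0.33 log units; beyond the scatter) and is read with 2-(ethoxycarbonyl)ethyl in place of phenyl on a saturated chain carbon, three bonds along the chain from a sulfur. No measurement at hand explains this order of the three compounds.

The compounds shown do not separate the contribution of the ethoxycarbonyl group from that of the chain that carries it, and a plain hexyl chain or a carboxylic acid in place of the ethyl ester would divide the two. An amide at the chain end would show whether the number depends on the ester linkage itself or holds for other carbonyl groups at that distance from the sulfur.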